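A few compounds are considered here, and "the series" means these few. Any claim that something is new, unique, unknown or untested is made for them only; others in the source may bear on it.

Compound 1 `[N-]=[N+]=NC[C@H]1CN(n2cccc2)C(=O)O1` gives 200000 nM in an assay for inhibition of Amine oxidase [flavin-containing] B (Bos taurus) (on this read-out lower numbers stand for stronger inhibition and higher numbers for weaker inhibition), the highest of the three numbers recorded. Compound 2 `NC[C@H]1CN(n2cccc2)C(=O)O1` gives 4400 nM and compound 3 `CN(C)C[C@H]1CN(n2cccc2)C(=O)O1` gives 140000 nM; the measured steps are a 45-fold lower number from compound 1 to compound 2 (1.66 log units; beyond the scatter), a 1.4-fold lower number from compound 1 to compound 3 (0.15 log units; within the scatter) and a 32-fold higher number from compound 2 to compound 3 (1.50 log units; beyond the scatter), each exchanging the group on the saturated chain carbon bound to a saturated ring carbon. Compound 4 `[N-]=[N+]=NC[C@@H]1CN(n2cccc2)C(=O)O1` keeps the azido group and differs from compound 1 only in this way: the two compounds have the same atoms and bonds; at least one stereo element is drawn with a configuration in one of them and without one in the other: 1 of 2 stereo elements differ; a stereocentre at a saturated ring carbon is drawn R in compound 1 and S in compound 4. Going by the values given here, no measured step inverts a stereocentre, so none bears directly on this change; the series gives no precedent for its size or direction. Compound 4 is therefore expected to lie near compound 1, with a wide range, at 200000 nM (40000 nM to 1000000 nM), a step of no change at the digits printed from compound 1 to compound 4 (within the scatter).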

Compound 4, inhibition constant: 24000 nM
For compound 4 the middle estimate is 8.3-fold (0.92 log units) above the measured one; measured number outside the range, below it.
By their numbers in this assay, from the lowest: compound 2; then compound 4; then compounds 3 and 1 (each within the scatter of the next).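

In this assay, the configuration at the saturated ring carbon matters on its own: with the azido group kept, the change from R to S gives an 8.3-fold lower number from compound 1 to compound 4 (0.92 log units; beyond the scatter). Going by these compounds alone, all earlier steps exchanged the group on the chain carbon, so this is the first sign that the series also responds to this stereocentre. The reading carries one caution: the fact that one of compounds 1 and 4 is drawn with a defined configuration and the other without, at the place where they differ

Still open, on these data alone, is whether the same inversion shifts the number in the amino and dimethylamino compounds. Also open, as far as these compounds go, is how a carboxylic acid or a longer chain in place of azido would read with either configuration.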